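The source may report more compounds than this note shows. Statements on the series, on what has been measured and on what is new or still open speak of the compounds shown alone.

Of the compounds shown here, two have so far been measured in a functional assay on A2780 cells (Homo sapiens) for cytotoxicity, read by sulforhodamine B assay, with a stated time of 72 h; a higher number here means a weaker inhibitor, a lower number a stronger inhibitor. Compound 1 `O=C(NCc1ccc(S(=O)(=O)c2ccccc2)cc1)c1cc2cnccc2[nH]1` gives 18 nM there. Compound 2 `CC(C)n1cc(S(=O)(=O)c2ccc(CNC(=O)N3Cc4ccncc4C3)cc2)cn1` gives 11 nM in this assay, the lowest of the two numbers, though the gap to compound 1 lies within the usual scatter, so the two compounds cannot really be told apart on these data. Compound 3 `O=C(NCc1ccc(S(=O)(=O)N2CCOCC2)cc1)N1Cc2ccncc2C1` has not yet been measured. It differs from compound 2 in a single place: morpholin-4-yl in place of 1-isopropyl-1H-pyrazol-4-yl on a sulfonyl sulfur. For the measured compounds named here, no measured pair shows what such a change does in this assay, so the direction of the step can only be guessed from the change itself. The expectation is a modest weakening, a 3.6-fold higher number from compound 2 to compound 3 (0.56 log units; beyond the scatter) in this assay, a little beyond the scatter. Compound 3 is therefore expected to give about 40 nM in this assay, with a plausible range from 12 nM to 130 nM.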

Compound 3, half-maximal inhibitory concentration: 68 nM
Beside the measured number, compound 3's estimate is 1.7-fold (0.23 log units) below it; low and high end bracket the measured number.
By their numbers in this assay, from the lowest: compounds 2 and 1 (each within the scatter of the next); then compound 3.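

In this assay, for the compounds shown here, the change from 1-isopropyl-1H-pyrazol-4-yl to morpholin-4-yl on the sulfonyl sulfur gives a 6.2-fold higher number from compound 2 to compound 3 (0.79 log units; beyond the scatter) and supplies the first measured step at this position. The group on the sulfonyl sulfur therefore matters in this assay, and in this one pair the aromatic five-membered ring gives the lower number and the non-aromatic six-membered ring the higher one. No measurement available here explains the size or direction of this step.

This single step changes ring size, aromaticity and the isopropyl group together, so their separate contributions cannot be told apart. A pyrazol-4-yl without the isopropyl and a piperidin-1-yl, which has a carbon in place of the morpholine oxygen, are two groups that could help separate them.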